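Removing the ethenyl link from compound 1

A few compounds are considered here, and "the series" means these few. Any claim that something is new, unique, unknown or untested is made for them only; others in the source may bear on it.

Measured in a functional assay on KETR3 cells (Homo sapiens) for inhibition, read by MTT assay, with a stated time of 120 h; a higher number here means a weaker inhibitor, a lower number a stronger inhibitor:
compound 1 `CNC(=O)/C=C/c1ccc(NC(=O)Nc2ccc(Cl)c(C(F)(F)F)c2)cc1`: 21200 nM
compound 2 `CC(NC(=O)c1ccc(-c2ccc(NC(=O)Nc3cc(C(F)(F)F)ccc3Cl)cc2)cc1)c1ccccc1`: 16800 nM
compound 3 `CC1CN(C(=O)/C=C/c2ccc(NC(=O)Nc3ccc(Cl)c(C(F)(F)F)c3)cc2)CC(C)O1`: > 50000 nM (a limit of the assay, not a number)

The values of compound 1 and compound 2 lie within the usual scatter of each other. Within the data shown here, compound 1 therefore stands level with the only other number available, since the entry for compound 3 is a limit.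

The next compound to be tested is compound 4 `CNC(=O)CCc1ccc(NC(=O)Nc2ccc(Cl)c(C(F)(F)F)c2)cc1`. Its change from compound 1 is this: 2-(methylcarbamoyl)ethyl in place of 2-(methylcarbamoyl)ethenyl on an aromatic carbon.

Among the measured compounds shown here, one measured step bears on the same side chain: an at least 2.3-fold higher number from compound 1 to compound 3 (0.37 log units; beyond the scatter), with 2,6-dimethylmorpholin-4-yl in place of methylamino on a carbonyl carbon. That step lies beyond the scatter, but it alters a different part of the chain and leaves the ethenyl link untouched. For the measured compounds named here, no measured step changes that link, so the data give no direction for the present change, and no step beyond the scatter is expected in this assay. The expected outcome is a 1.1-fold higher number from compound 1 to compound 4 (0.04 log units; within the scatter). In this assay the estimate for compound 4 is 23000 nM, with an expected range from 10000 nM to 50000 nM.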

Compound 4, half-maximal inhibitory concentration: 24000 nM
For compound 4 the middle estimate is 1.0-fold (0.02 log units) below the measured one; the measured number falls inside the stated range.
By their numbers in this assay, from the lowest: compounds 2, 1 and 4 (each within the scatter of the next). At a limit, above all of these: compound 3.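

In this assay, the step at the link itself reads a 1.1-fold higher number from compound 1 to compound 4 (0.05 log units; within the scatter), so this position, para to a large group, accepts 2-(methylcarbamoyl)ethyl and 2-(methylcarbamoyl)ethenyl alike, and the double bond of the ethenyl link is not needed to keep the level of inhibition seen with compound 1. Among these compounds, the earlier step on this side chain changed only the group on the carbonyl carbon and left the ethenyl link in place, so compound 4 gives the first reading of the link itself. Nothing measured here explains why the two links read alike.

As far as these compounds go, compound 3 gives > 50000 nM, which is a limit of the assay and not a number, so the size of the change on the carbonyl carbon remains unknown. From the compounds shown here alone, it also remains open whether a longer chain in place of 2-(methylcarbamoyl)ethyl, or a carboxylic acid in place of the methylamino end of that chain, would hold the level of compound 4 in this assay or move it beyond the scatter.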